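This account rests on a few compounds, and the source may have more. Where it says the series, first, only, none or still open, it means among the compounds named here.

Working notes on the series.

The shared core carries an anilide on which the aryl attached to the carbonyl carbon is varied. Compound 1 `O=C(Nc1ccc(Cl)c(-c2nnc3c(Cl)cccn23)c1)c1cccnc1` bears a pyridin-3-yl there. In a functional assay on T47D cells (Homo sapiens) for antiproliferative activity, read by MTT assay, with a stated time of 72 h (on this read-out lower numbers stand for stronger inhibition and higher numbers for weaker inhibition), compound 1 gives > 100000 nM, which is a limit of the assay and not a number. Compound 2 `O=C(Nc1ccc(Cl)c(-c2nnc3c(Cl)cccn23)c1)c1ccc(Cl)cc1` has a 4-chlorophenyl in its place. In this assay compound 2 gives > 100000 nM, again a limit. Compound 3 `CS(=O)(=O)c1ccc(C(=O)Nc2ccc(Cl)c(-c3nnc4c(Cl)cccn34)c2)cc1` carries a 4-(methylsulfonyl)phenyl. In this assay compound 3 gives > 100000 nM, also a limit. Compound 3 therefore stands with the other two at the limit of > 100000 nM in this assay, at which 3 of the 3 values shown sit, and none of the three is ordered against another.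

The steps a step that the two limits leave unreadable from compound 1 to compound 2, a step that the two limits leave unreadable from compound 1 to compound 3 and a step that the two limits leave unreadable from compound 2 to compound 3 are all unreadable in size, since both ends of each lie at the limit.

Compound 4 `O=C(Nc1ccc(Cl)c(-c2nnc3c(Cl)cccn23)c1)c1c(F)cccc1Cl` differs from compound 3 by 2-chloro-6-fluorophenyl in place of 4-(methylsulfonyl)phenyl on a carbonyl carbon. Among the compounds with values here, the steps that bear on it are those from compound 1 and compound 2 to compound 3, which change the same aryl on the carbonyl carbon and give no readable size. Within the data shown here, no step has so far moved any value off the limit, so compound 4 is expected to sit there as well, and the step that the limit leaves unreadable from compound 3 to compound 4 is expected to be unreadable. For compound 4 the estimate in this assay is 150000 nM, with a range from 40000 nM to 500000 nM.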

Compound 4, half-maximal inhibitory concentration: > 100000 nM
Compound 4: a limit, no number; the forecaster's own chance of this, stated with the estimate: 80%; the middle value lies beyond the limit too.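

Compound 4 gives > 100000 nM in this assay, which is a limit of the assay and not a number. No step among compound 1, compound 2, compound 3 and compound 4 can therefore be read in size: the limit of > 100000 nM in this assay, at which 4 of the 4 values shown sit.

The compounds shown leave open whether any aryl on the carbonyl carbon of the shared core brings a value off this limit in this assay.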